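A few compounds are considered here, and "the series" means these few. Any claim that something is new, unique, unknown or untested is made for them only; others in the source may bear on it.

In an assay on RMS13 cells for displacement of a labelled ligand from Urotensin-2 receptor (Homo sapiens), read by scintillation proximity assay (on this read-out lower numbers stand for stronger inhibition and higher numbers for weaker inhibition), compound 1 `CCN1CCN(c2cccc3c2CN([C@H](CCCN(C)S(=O)(=O)c2cccs2)c2ccc(OC)c(OC)c2)C3=O)CC1` gives a value that is a limit of the assay, < 5 nM. For the measured compounds named here, compound 2 `CCN1CCN(c2cccc3c2CN([C@H](CCCNC(=O)c2cccs2)c2ccc(OC)c(OC)c2)C3=O)CC1` is the only compound with an actual number in this assay, where compound 2 gives 18 nM. Going by the values given here, the single measured step, an at least 3.6-fold higher number from compound 1 to compound 2 (0.55 log units; beyond the scatter), exchanges the substituent on the chain four bonds from the ring nitrogen and the aromatic carbon; its full size cannot be fixed because of the limit of < 5 nM in this assay, at which 1 of the 2 values shown sits. Compound 3 `CCN1CCN(c2cccc3c2CN([C@H](CCCNCc2cccs2)c2ccc(OC)c(OC)c2)C3=O)CC1` differs from compound 2 in one place: (thiophen-2-yl)methyl in place of (thiophen-2-yl)carbonyl on an amine nitrogen. This change sits on the same chain as the measured step, so that step bears on it, though it alters only the link to the thiophene rather than the whole substituent. Since the group at this place shifted the number beyond the scatter from compound 1 to compound 2, a shift beyond the scatter for compound 3 in this assay is plausible, with the direction not settled by the data. Compound 3 is therefore expected to give about 35 nM, between 8 nM and 150 nM. The step of a 1.9-fold higher number from compound 2 to compound 3 (0.29 log units; within the scatter) is thus estimated to be modest.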

Compound 3, inhibition constant: 18 nM
Compound 3: middle estimate off by 1.9-fold (0.29 log units), on the high side; the range from low to high includes it.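

Exchanging (thiophen-2-yl)carbonyl for (thiophen-2-yl)methyl on the amine nitrogen gives no change at the digits printed from compound 2 to compound 3 (within the scatter) in this assay, so at this place the number does not depend on the carbonyl. The other new step, an at least 3.6-fold higher number from compound 1 to compound 3 (0.55 log units; beyond the scatter), matches the step already seen with compound 2, which sets methyl((thiophen-2-yl)sulfonyl)amino apart from both of the other groups rather than from the carbonyl-linked group alone. The value of compound 1 is a limit of the assay, and the full size of this separation stays unfixed because of it: the limit of < 5 nM in this assay, at which 1 of the 3 values shown sits.

The compounds shown do not separate the sulfonyl from the methyl on the nitrogen of compound 1, so it remains open which of the two goes with the step, or whether both are needed. As far as these compounds go, how a phenyl ring in place of the thiophene, or a longer chain between the shared core and the amine nitrogen, would read in this assay also stays open.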